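The source may hold more compounds than are shown below. What is called first, only, known or untested is meant among the compounds shown, and "the series" means these compounds.

Measured in an ADME assay on L6 cells (Rattus norvegicus) for cytotoxicity, read by resazurin assay, with a stated time of 70 h; a lower number here means a stronger inhibitor, a higher number a weaker inhibitor:
compound 1 `COc1cc(CN2c3ccc(OC(C)=O)cc3C(C)=CC2(C)C)cc(OC)c1`: 25000 nM
compound 2 `CC(=O)Oc1ccc2c(c1)C(C)=CC(C)(C)N2Cc1cccc(C)c1`: 28000 nM

Compound 2 stands at 28000 nM, within the scatter of compound 1 at 25000 nM, so these two values do not separate. The next compound in the series, compound 3 `COc1cccc(CN2c3ccc(OC(C)=O)cc3C(C)=CC2(C)C)c1`, has not yet been measured. It differs from compound 2 by one change: methoxy in place of methyl on an aromatic carbon. In words, methoxy stands in place of methyl on an aromatic carbon, meta to a large group, taking 3-methylphenyl to 3-methoxyphenyl. For the measured compounds named here, no measured step shows what such a change does in this assay, so the expectation rests only on the closeness of the two values and points to no shift beyond the scatter, in either direction. The expected 1.1-fold lower number from compound 2 to compound 3 (0.03 log units; within the scatter) is small. For compound 3 the estimated value is 26000 nM, with an expected range of 14000 nM to 50000 nM.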

Compound 3, half-maximal inhibitory concentration: 29000 nM
Beside the measured number, compound 3's estimate is 1.1-fold (0.05 log units) below it; low and high end bracket the measured number.
By their numbers in this assay, from the lowest: compounds 1, 2 and 3 (each within the scatter of the next).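

Methoxy in place of methyl on an aromatic carbon, meta to a large group, gives a 1.0-fold higher number from compound 2 to compound 3 (0.02 log units; within the scatter) in this assay and is the first direct reading of this change, which does not separate the two compounds. Hydrogen in place of methoxy on an aromatic carbon gives a 1.2-fold higher number from compound 1 to compound 3 (0.06 log units; within the scatter) so the second methoxy of compound 1 does not separate compound 1 from compound 3 either. Nothing at hand explains why these values stay together.

The groups shown on this ring are only methyl and methoxy, so whether an amine, a carboxylic acid or a longer alkoxy chain on this carbon would move the number beyond the scatter in this assay stays open. On these data alone, the shared core is the same in all three compounds, so what it contributes to the reading also stays open.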